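Isopropyl for Cyclopropyl on Two Aryl Cores

A few compounds are considered here, and "the series" means these few. Any claim that something is new, unique, unknown or untested is made for them only; others in the source may bear on it.

Compound 1 `COc1cc(N(CC2CC2)c2ccc(F)c3ccccc23)cnc1C(=O)[C@H]1C[C@@H]1C(=O)O` and compound 2 `COc1cc(N(CC(C)C)c2ccc(F)c3ccccc23)cnc1C(=O)[C@H]1C[C@@H]1C(=O)O` share one core and differ in a single place: isopropyl in place of cyclopropyl on a saturated chain carbon bound to a nitrogen on an aromatic ring. In an assay on isolated protein for inhibition of leukotriene C4 synthase (Homo sapiens), read by LC-MS, with stated times of 45 min and 20 min (a lower number here means a stronger inhibitor, a higher number a weaker inhibitor), compound 1 gives 26.5 nM and compound 2 gives 2.26 nM, so that a 12-fold lower number from compound 1 to compound 2 (1.07 log units; beyond the scatter). Compound 3 `COc1cc(N(CC2CC2)c2cc(C(F)(F)F)ccc2F)cnc1C(=O)[C@H]1C[C@@H]1C(=O)O` carries a different core, and the difference between the two cores is not broken down here. In this assay compound 3 gives 14 nM, a number within the scatter of compound 1 but well above that of compound 2. Compound 4 `COc1cc(N(CC(C)C)c2cc(C(F)(F)F)ccc2F)cnc1C(=O)[C@H]1C[C@@H]1C(=O)O` repeats the same change on the core of compound 3: isopropyl in place of cyclopropyl on a saturated chain carbon bound to a nitrogen on an aromatic ring. Because the only earlier case a 12-fold lower number from compound 1 to compound 2 (1.07 log units; beyond the scatter) was large, a clearly lower number is expected for compound 4, tempered since one example is thin ground. The expected step is a 5.6-fold lower number from compound 3 to compound 4 (0.75 log units; beyond the scatter). Compound 4 is estimated at 2.5 nM, between 0.8 nM and 8 nM.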

Compound 4, half-maximal inhibitory concentration: 6.8 nM
Compound 4: the middle estimate sits 2.7-fold (0.43 log units) below what was measured; the measured number falls inside the stated range.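

On the second core the same change in this assay again goes the same way, giving a 2.1-fold lower number from compound 3 to compound 4 (0.31 log units; beyond the scatter). The direction therefore carries over between these two cores, but the size does not: the same change on two cores in this assay, a 12-fold lower number (1.07 log units; beyond the scatter) from compound 1 to compound 2 and a 2.1-fold lower number (0.31 log units; beyond the scatter) from compound 3 to compound 4, 5.7-fold (0.76 log units) apart, beyond the scatter of two such steps. Two cores are a small sample, so this does not show how the change would behave on any other core, and the data do not say what sets the size of the step on each core.

The compounds shown leave open whether a cyclobutyl group or a longer chain, placed on the same saturated chain carbon, would follow the same direction on both cores. They also leave open whether a nitrile in place of trifluoromethyl would alter the size of the step.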